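Swapping pyrrolidin-1-yl for morpholin-4-yl in compound 2

This account rests on a few compounds, and the source may have more. Where it says the series, first, only, none or still open, it means among the compounds named here.

Compound 1 `CCn1c(/C=C2\SC(=O)N(CC(=O)Nc3cc(C(C)(C)C)on3)C2=O)nc2ccccc21` gives > 50000 nM in a functional assay on DU-145 cells (Homo sapiens) for inhibition, read by MTT assay, with a stated time of 48 h (a higher number here means a weaker inhibitor, a lower number a stronger inhibitor), as a limit
Compound 2 `CCn1c(/C=C2\SC(=O)N(CC(=O)N3CCCC3)C2=O)nc2ccccc21` gives 45100 nM in this assay as a number

Among the compounds with values here, compound 2 at 45100 nM is the only compound here with a true number. Compound 1 reads > 50000 nM as a limit of the assay, not a number. For compound 1 this is the limit of > 50000 nM in this assay, at which 1 of the 2 values shown sits, and no more.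

Compound 3 `CCn1c(/C=C2\SC(=O)N(CC(=O)N3CCOCC3)C2=O)nc2ccccc21` keeps the shared core and changes one group, morpholin-4-yl in place of pyrrolidin-1-yl on a carbonyl carbon with morpholin-4-yl in place of pyrrolidin-1-yl on a carbonyl carbon. Within the data shown here, the only measured step is an at least 1.1-fold lower number from compound 1 to compound 2 (0.04 log units; that floor lies within the scatter) with pyrrolidin-1-yl in place of (5-(tert-butyl)-1,2-oxazol-3-yl)amino on a carbonyl carbon. That step is a floor at the same spot and involves a different group, so it offers little guidance. With compound 2 at 45100 nM as the anchor, no shift beyond the scatter is expected in this assay in either direction. A report of only a limit for compound 3 would be no surprise. The estimated change is a 1.1-fold higher number from compound 2 to compound 3 (0.03 log units; within the scatter) in this expectation. Compound 3 is expected at about 48000 nM with an estimated range from 25000 nM to 90000 nM across repeated measurements.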

Compound 3, half-maximal inhibitory concentration: > 50000 nM
Compound 3: only a limit was reported; the forecaster's own chance of this, stated with the estimate: 50%; middle value at least 1.0-fold (0.01 log units) away from the limit.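

In this assay compound 3 gives > 50000 nM, which is a limit of the assay and not a number. Morpholin-4-yl in place of pyrrolidin-1-yl on a carbonyl carbon gives an at least 1.1-fold higher number from compound 2 to compound 3 (0.04 log units; that floor lies within the scatter), so this ring swap produces no change that can be told apart from ordinary repeat variation; the step between compound 1 and compound 3 cannot be read, as both values are limits. What is new is that a second kind of group on this carbonyl carbon, a six-membered ring after the (5-(tert-butyl)-1,2-oxazol-3-yl)amino of compound 1, also ends at the limit, which leaves compound 2 as the only one with a true number: the limit of > 50000 nM in this assay, at which 2 of the 3 values shown sit.

The compounds shown leave open whether any group on this carbonyl carbon can bring the number clearly down, and how far compound 3 and compound 1 actually lie past the limit. A piperidin-1-yl ring, a 4-methylpiperazin-1-yl ring or a simple benzylamino group in this place would show whether the reading can move at all.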